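This account rests on a few compounds, and the source may have more. Where it says the series, first, only, none or still open, it means among the compounds named here.

Compound 1 `CC(C)C/N=c1\c(O)c(O)\c1=N/Cc1ccc(C#N)cc1`: 10200 nM
Compound 2 `CC(C)(C)/N=c1\c(O)c(O)\c1=N/Cc1ccc(C#N)cc1Cl`: 140 nM

In a functional assay for inhibition, with Rattus norvegicus as the target (on this read-out lower numbers stand for stronger inhibition and higher numbers for weaker inhibition), compound 2 gives 140 nM, the lowest of the two numbers. Compound 1 gives 10200 nM, a gap well beyond the scatter, but the two structures differ in more than one place, so no single step can be read from them. Compound 3 `CC(C)(C)/N=c1\c(O)c(O)\c1=N/Cc1ccc(C#N)cc1` carries hydrogen in place of chloro on an aromatic carbon. Within the data shown here, no measured step covers this change, so a moderate loss toward compound 1 is expected, since compound 2 at 140 nM stands far below it. Compound 3 is expected to give 700 nM, within 150 nM to 3500 nM, an expected step of a 5.0-fold higher number from compound 2 to compound 3 (0.70 log units; beyond the scatter).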

Compound 3, half-maximal inhibitory concentration: 270 nM
Compound 3: middle estimate off by 2.6-fold (0.41 log units), on the high side; low and high end bracket the measured number.
By their numbers in this assay, from the lowest: compounds 2 and 3 (each within the scatter of the next); then compound 1.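

In this assay, hydrogen in place of chloro on the aromatic carbon gives a 1.9-fold higher number from compound 2 to compound 3 (0.29 log units; within the scatter) and so stays within the scatter, which shows that the chloro is not needed to keep compound 3 at this level. Tert-butyl in place of isobutyl on the double-bonded nitrogen instead gives a large step, a 38-fold lower number from compound 1 to compound 3 (1.58 log units; beyond the scatter) and beyond the scatter. No measurement shown here offers a reason for either step.

On these data alone, it remains open whether a cyclopropyl group or a longer chain on that nitrogen would hold this level. As far as these compounds go, it is also open whether fluoro or methoxy on that aromatic carbon would stay within the scatter of compound 3.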